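Amide substituent swap on the methylphenyl core

A few compounds are considered here, and "the series" means these few. Any claim that something is new, unique, unknown or untested is made for them only; others in the source may bear on it.

Compound 1 `COC(=O)/C=C/c1cccc(N(Cc2ccc(-c3ccc(OC)cc3)cc2)C(=O)C2CCCCC2)c1` is the reference in an assay on isolated protein with Bile acid receptor (Homo sapiens) as the target (on this read-out lower numbers stand for an effect already at smaller amounts and higher numbers for an effect only at larger amounts of compound), where compound 1 gives 89 nM. Compound 2 `COC(=O)/C=C/c1cccc(N(Cc2ccc(-c3ccc(OC)cc3)cc2)C(=O)C(C)C)c1` carries isopropyl in place of cyclohexyl on a carbonyl carbon and gives 97 nM in this assay, so the step of a 1.1-fold higher number from compound 1 to compound 2 (0.04 log units; within the scatter) is a flat one. Compound 3 `COC(=O)/C=C/c1cccc(N(Cc2ccc(-c3cccc(C)c3)cc2)C(=O)C2CCCCC2)c1` differs from compound 1 in the core, namely (3-methylphenyl in place of 4-methoxyphenyl on an aromatic carbon); in this assay compound 3 gives 109 nM, and the step of a 1.2-fold higher number from compound 1 to compound 3 (0.09 log units; within the scatter) is likewise flat. Within the data shown here, compound 2 and compound 3 have no step counted between them, and their two values lie close together.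

Compound 4 `COC(=O)/C=C/c1cccc(N(Cc2ccc(-c3cccc(C)c3)cc2)C(=O)C(C)C)c1` is not yet measured. Among the measured compounds shown here, it is made from compound 3 by isopropyl in place of cyclohexyl on a carbonyl carbon, which is the same change, at the same place, as the one from compound 1 to compound 2. That earlier change gave a 1.1-fold higher number from compound 1 to compound 2 (0.04 log units; within the scatter), a step within the scatter. For the measured compounds named here, with only this single precedent, and with the core change from compound 1 to compound 3 itself flat, there is nothing in the data pointing to a different outcome on the methylphenyl core. For compound 4 the expected step is therefore a 1.1-fold higher number from compound 3 to compound 4 (0.04 log units; within the scatter). This expectation rests on compound 1 and compound 2, where the same change gave a 1.1-fold higher number from compound 1 to compound 2 (0.04 log units; within the scatter). Compound 4 is accordingly estimated at 120 nM in this assay, with a likely range from 60 nM to 240 nM.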

Compound 4, half-maximal effective concentration: 163 nM
For compound 4 the middle estimate is 1.4-fold (0.13 log units) below the measured one; low and high end bracket the measured number.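

In this assay, isopropyl in place of cyclohexyl on a carbonyl carbon gives a 1.5-fold higher number from compound 3 to compound 4 (0.17 log units; within the scatter), and this flat step on the core of compound 3 cannot be told apart from the step seen on the core of compound 1: the same change on two cores in this assay, a 1.1-fold higher number (0.04 log units; within the scatter) from compound 1 to compound 2 and a 1.5-fold higher number (0.17 log units; within the scatter) from compound 3 to compound 4, 1.4-fold (0.14 log units) apart, within the scatter of two such steps

The other change, 3-methylphenyl in place of 4-methoxyphenyl on an aromatic carbon, gives a 1.7-fold higher number from compound 2 to compound 4 (0.23 log units; within the scatter) with isopropyl on the carbonyl carbon, and it also carries over from the cyclohexyl compounds without a readable difference: the same change on two cores in this assay, a 1.2-fold higher number (0.09 log units; within the scatter) from compound 1 to compound 3 and a 1.7-fold higher number (0.23 log units; within the scatter) from compound 2 to compound 4, 1.4-fold (0.14 log units) apart, within the scatter of two such steps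

This shows that both changes stay flat on the two cores compared, but it rests on only these four compounds, does not exclude a core dependence smaller than the scatter, and gives no general rule for other groups or cores.

The compounds shown leave open whether a different group on the carbonyl carbon, such as an amine or a longer chain, or a carboxylic acid in place of the methyl ester, would give a step beyond the scatter. They also leave open whether either change would remain flat on a read-out other than this assay.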